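The source may hold more compounds than are shown below. What is called first, only, known or untested is meant among the compounds shown, and "the series" means these compounds.

Of the compounds shown here, two have been measured in a physicochemical assay for solubility, in phosphate buffer, measured as kinetic solubility, with a stated time of 1 h, at pH 7.4; a lower number here means a less soluble compound, a higher number a more soluble compound. Compound 1, `CS(=O)(=O)Cc1cc(C2=CCOCC2)nc(-c2cccc(O)c2)n1`, gives 27 ug/mL in this assay. Compound 2, `CC(C)(c1cc([C@]23CCOC[C@H]2C3)nc(-c2ccc(NC(=S)NCCO)cc2)n1)S(C)(=O)=O`, gives 173 ug/mL in this assay, which is the higher of the two numbers, and the gap between compound 1 and compound 2 lies beyond the usual scatter of the measurement. Among the measured compounds shown here, no pair of measured compounds differs in only one place, so the two values stand on their own and no measured step can be drawn from them. The unmeasured compound 3, `CC(C)(c1cc([C@@]23CCOC[C@@H]2C3)nc(-c2ccc(NC(=S)NCCO)cc2)n1)S(C)(=O)=O`, is the mirror image of compound 2: the two compounds have the same atoms and bonds and differ only in configuration as drawn: 2 of 2 stereo elements differ (all stereocentres are inverted: mirror images); a stereocentre at a saturated ring carbon is drawn R in compound 2 and S in compound 3; a stereocentre at a saturated ring carbon is drawn S in compound 2 and R in compound 3. Given that compound 2 gives 173 ug/mL and that compound 3 has the same atoms and bonds, the step of a 1.0-fold lower number from compound 2 to compound 3 (0.01 log units; within the scatter) is expected to be none beyond the scatter. Compound 3 is therefore estimated to give about 170 ug/mL in this assay, with a range from 95 ug/mL to 310 ug/mL.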

Compound 3, solubility: 145 ug/mL
For compound 3 the middle estimate is 1.2-fold (0.07 log units) above the measured one; low and high end bracket the measured number.
By their numbers in this assay, from the lowest: compound 1; then compounds 3 and 2 (each within the scatter of the next).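

In this assay, the change of both stereocentres at the saturated ring carbons gives a 1.2-fold lower number from compound 2 to compound 3 (0.08 log units; within the scatter), which places the two mirror images level with each other. Compound 1 and compound 2 differ in more than one place and could not isolate any single change, whereas this pair shows that, for these two compounds, the configuration as drawn at this position does not separate the values beyond the scatter. The comparison isolates configuration alone: the fact that compounds 2 and 3 differ only in the configuration as drawn

The compounds shown leave open whether the two mirror images would remain level if an amine or a carboxylic acid were carried on the shared core. They also leave open what replacing the group bearing these stereocentres with a simple amine would do in this assay.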